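Trifluoromethyl to chloro on the urea aryl of compound 2

The source may report more compounds than this note shows. Statements on the series, on what has been measured and on what is new or still open speak of the compounds shown alone.

Three measured compounds share one core. In a functional assay on A375P cells (Homo sapiens) for antiproliferative activity, read by MTT assay, with a stated time of 24 h (a higher number here means a weaker inhibitor, a lower number a stronger inhibitor), compound 1 `CC(=O)Nc1ncnc2c1ccn2-c1ccc(NC(=O)Nc2ccc(Cl)c(C(F)(F)F)c2)cc1` reaches only the limit > 10000 nM. Compound 3 `CC(=O)Nc1ncnc2c1ccn2-c1ccc(NC(=O)Nc2cccc(Cl)c2Cl)cc1` likewise gives only the limit > 10000 nM. For the measured compounds named here, compound 2 `O=C(Nc1ccc(-n2ccc3c(NC(=O)c4ccccc4)ncnc32)cc1)Nc1ccc(Cl)c(C(F)(F)F)c1` gives 4600 nM, the sole number among the three, as the other two sit at the limit of > 10000 nM in this assay, at which 2 of the 3 values shown sit. The step of an at least 2.1-fold lower number from compound 1 to compound 2 (0.33 log units; beyond the scatter) is readable; the step that the two limits leave unreadable from compound 1 to compound 3 is not. Compound 4 `O=C(Nc1ccc(-n2ccc3c(NC(=O)c4ccccc4)ncnc32)cc1)Nc1ccc(Cl)c(Cl)c1` differs from compound 2 by chloro in place of trifluoromethyl on an aromatic carbon. Going by the values given here, no measured step resolves this change, since the only comparison on that aryl, from compound 1 to compound 3, stays within limits. Compound 4 is therefore expected near 6000 nM, between 2000 nM and 20000 nM. The expected step is a 1.3-fold higher number from compound 2 to compound 4 (0.12 log units; within the scatter), within the scatter.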

Compound 4, half-maximal inhibitory concentration: 4000 nM
Compound 4: middle estimate off by 1.5-fold (0.18 log units), on the high side; the range from low to high includes it.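

In this assay, replacing trifluoromethyl with chloro on the urea aryl gives a 1.2-fold lower number from compound 2 to compound 4 (0.06 log units; within the scatter), so with phenyl on the carbonyl, the 4-chloro-3-(trifluoromethyl)phenyl and 3,4-dichlorophenyl groups are not told apart. This is the first readable comparison on that aryl, since the earlier one ended in limits on both sides: the limit of > 10000 nM in this assay, at which 2 of the 4 values shown sit.

On these data alone, whether the change behaves the same way with methyl on the carbonyl remains open. So does the outcome of placing an amine or a carboxylic acid at this position of the urea aryl.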